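A Fluoro Step on the Hydroxy Compound

The source may hold more compounds than are shown below. What is called first, only, known or untested is meant among the compounds shown, and "the series" means these compounds.

In a functional assay on Gurav cells (Homo sapiens) for inhibition, read by sulforhodamine B assay (on this read-out higher numbers stand for weaker inhibition of growth and lower numbers for stronger inhibition of growth), compound 1 (`c1ccc(-c2ccc(-c3ccc(-c4nc5ccccc5[nH]4)cc3)cc2)cc1`) gives 100000 nM and compound 2 (`Fc1ccc(-c2ccc(-c3ccc(-c4nc5ccccc5[nH]4)cc3)cc2)cc1`) gives 100000 nM on the same read-out. Compound 3 (`Oc1cccc2[nH]c(-c3ccc(-c4ccc(-c5ccccc5)cc4)cc3)nc12`) gives 1110 nM and holds the lowest of the three numbers, after hydroxy replaced hydrogen on an aromatic carbon in the step that shows a 90-fold lower number from compound 1 to compound 3 (1.95 log units; beyond the scatter) here. Compound 4 (`Oc1cccc2[nH]c(-c3ccc(-c4ccc(-c5ccc(F)cc5)cc4)cc3)nc12`) adds fluoro in place of hydrogen on an aromatic carbon to compound 3, para to a large group: fluoro in place of hydrogen on an aromatic carbon here. Within the data shown here, the only measured fluoro step shows no change at the digits printed from compound 1 to compound 2 (within the scatter) but lacks the hydroxy group, so it is a limited guide. On that basis, a 1.0-fold lower number from compound 3 to compound 4 (0.00 log units; within the scatter) is expected to stay within the scatter, in neither direction. In this assay compound 4 is estimated at 1100 nM (expected range 400 nM to 3300 nM).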

Compound 4, concentration for 50% growth inhibition: 2860 nM
For compound 4 the middle estimate is 2.6-fold (0.41 log units) below the measured one; measured number inside the range.
By their numbers in this assay, from the lowest: compound 3; then compound 4; then compounds 1 and 2 (each within the scatter of the next).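

With the hydroxy group present, the phenyl to 4-fluorophenyl change is no longer silent in this assay, where it gives a 2.6-fold higher number from compound 3 to compound 4 (0.41 log units; beyond the scatter). Even so, this step does not separate from the earlier fluoro step: the same change on two cores in this assay, no change at the digits printed (within the scatter) from compound 1 to compound 2 and a 2.6-fold higher number (0.41 log units; beyond the scatter) from compound 3 to compound 4, 2.6-fold (0.41 log units) apart, within the scatter of two such steps. The hydroxy change also holds with fluoro in place, giving a 35-fold lower number from compound 2 to compound 4 (1.54 log units; beyond the scatter), and its size does not separate from that of the earlier hydroxy step: the same change on two cores in this assay, a 90-fold lower number (1.95 log units; beyond the scatter) from compound 1 to compound 3 and a 35-fold lower number (1.54 log units; beyond the scatter) from compound 2 to compound 4, 2.6-fold (0.41 log units) apart, within the scatter of two such steps.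

The compounds shown leave open how a methoxy group or an amine would read on this same aromatic carbon. They also leave open whether an amine or a carboxylic acid could stand in for the hydroxy group.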